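The compounds below may be only part of what the source reports. "The series", "measured", "known", "first", "only" and "open" are said of these compounds alone.

Compound 1 `COC(=O)C1=C(C)NC(=O)NC1c1cccs1` is the reference point of this account. In an assay on membranes from CHO cells for displacement of a labelled ligand from adenosine receptor A1 (Homo sapiens), read by scintillation counting, with a stated time of 60 min, tested at 1 uM (a higher number here means more inhibition at the concentration tested (going by the name of the read-out), a lower number less inhibition), compound 1 gives 6%, the lowest of the two numbers recorded so far. For the measured compounds named here, its nearest neighbour is compound 2 `COC(=O)C1=C(C)N(C)C(=O)NC1c1cccs1`, which in this assay gives 30%; the single measured step, a number 24 percentage points higher from compound 1 to compound 2 (beyond the scatter), comes from methyl in place of hydrogen on an amide-type nitrogen in a ring.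

Compound 3 `CC1=C(C(=O)OCC2CC2)C(c2cccs2)NC(=O)N1` has not yet been measured. It differs from compound 1 by cyclopropyl in place of hydrogen on a saturated chain carbon bound to an oxygen next to a carbonyl group. Going by the values given here, that change sits on the ester side of the shared core, a part untouched by the one measured step, so the step from compound 1 to compound 2 bears only indirectly on it: it shows that a small addition to compound 1 can move the number beyond the scatter, but it says nothing about the ester. Among the compounds with values here, with no step at the same place to lean on, compound 3 is expected to stay near compound 1, with a step of a number 6 percentage points higher from compound 1 to compound 3 (within the scatter), that is an estimate of 12% ranging from 0% to 35%.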

Compound 3, a percentage reported as inhibition, at one concentration (the size of the read-out at that concentration, not a potency): 23%
Compound 3: middle estimate off by 11 percentage points, on the low side, within the range that was stated.
By their numbers in this assay, from the lowest: compound 1; then compounds 3 and 2 (each within the scatter of the next).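

For the compounds shown here, the ester side of the shared core, which the earlier compounds left untouched, now also proves able to move the number: in this assay cyclopropyl in place of hydrogen on a saturated chain carbon bound to an oxygen next to a carbonyl group gives a number 17 percentage points higher from compound 1 to compound 3 (beyond the scatter) and so adds a second place where a single change to compound 1 has a measurable effect. Together with the other single change, which gives a number 24 percentage points higher from compound 1 to compound 2 (beyond the scatter) as methyl replaces hydrogen on an amide-type nitrogen in a ring, this means that both measured changes to compound 1 go upward, with no compound shown going against that. No measurement presented here explains why the number rises at either place.

The compounds shown leave open whether the rise on the ester side needs the three-membered ring or would also come with an open chain such as ethyl or n-propyl, and how a carboxylic acid or an amine-bearing chain would fare at this place. They also leave open whether the ester change and the methyl on the ring nitrogen would add up in a single compound.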